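A methoxy added to the benzyl arm of compound 1

The compounds below may be only part of what the source reports. "The series", "measured", "known", "first", "only" and "open" are said of these compounds alone.

Compound 1 `O=C1C[C@H](OCc2cn(Cc3ccccc3)nn2)[C@H]2CO[C@@H]1O2` — in a functional assay on MDA-MB-231 cells (Homo sapiens) for cytotoxicity, read by MTT assay, with a stated time of 48 h (on this read-out higher numbers stand for weaker inhibition and lower numbers for stronger inhibition), compound 1 reaches only the assay limit, > 50000 nM.
Compound 2 `O=C1C[C@H](OCc2cn(C(=O)c3ccccc3)nn2)[C@H]2CO[C@@H]1O2` — in this assay compound 2 gives 25900 nM.
Compound 3 `O=C1C[C@H](OCc2cn(-c3ccccc3)nn2)[C@H]2CO[C@@H]1O2` — in this assay compound 3 gives 25200 nM.

Compound 1 is the only one of the three that is reported as a limit rather than a number (the limit of > 50000 nM in this assay, at which 1 of the 3 values shown sits), so its true position is open. The two measured steps leave that point are an at least 1.9-fold lower number from compound 1 to compound 2 (0.28 log units; that floor lies within the scatter) and an at least 1.9-fold lower number from compound 1 to compound 3 (0.29 log units; that floor lies within the scatter), each only at the floor that the limit allows, and the remaining pair shows a 1.0-fold lower number from compound 2 to compound 3 (0.01 log units; within the scatter). All three compounds therefore sit in the same weak region.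

Compound 4 `COc1ccc(Cn2cc(CO[C@H]3CC(=O)[C@@H]4OC[C@H]3O4)nn2)cc1` keeps the benzyl arm of compound 1 and differs from it by methoxy in place of hydrogen on an aromatic carbon. Going by the values given here, none of the measured steps changes a substituent on that phenyl ring; they exchange the whole group on the triazole nitrogen instead, and even those exchanges moved the numbers little. There is thus no basis for expecting a step beyond the scatter, and the expectation for compound 4 is a number no higher from compound 1 to compound 4 (the limit leaves the size open). Compound 4 is accordingly estimated at 50000 nM, within 20000 nM to 150000 nM, with a real chance that this assay again returns only a limit.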

Compound 4, half-maximal inhibitory concentration: 34800 nM
The estimate for compound 4 lay 1.4-fold (0.16 log units) above the measured number; the range from low to high includes it.
By their numbers in this assay, from the lowest: compounds 3, 2 and 4 (each within the scatter of the next). At a limit, above all of these: compound 1.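

Compound 4 carries the first change shown on the phenyl ring itself, phenyl to 4-methoxyphenyl, and in this assay compound 4 gives 34800 nM, so a benzyl arm on the triazole nitrogen now has a measured number rather than a limit. The step reads an at least 1.4-fold lower number from compound 1 to compound 4 (0.15 log units; that floor lies within the scatter), which means that, as far as it can be read, methoxy in place of hydrogen at this position has not been shown to move the number beyond the scatter. The true size of the step stays open, since compound 1 is reported only as a limit: the limit of > 50000 nM in this assay, at which 1 of the 4 values shown sits.

The compounds shown do not tell how the number would respond to a different group at the same place on the ring, such as a hydroxyl, an amine or a carboxylic acid in place of the methoxy. Nor do they tell whether a longer chain there, such as butoxy, would leave the number in the same weak region or take it clearly lower.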